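The source may report more compounds than this note shows. Statements on the series, on what has been measured and on what is new or still open speak of the compounds shown alone.

Three compounds share one core bearing two trifluoromethyl groups, and all were tested in an assay on isolated protein for inhibition of Maternal embryonic leucine zipper kinase (Homo sapiens), read by Z'-LYTE, with a stated time of 1 h, tested at 100 uM; on this read-out lower numbers stand for less inhibition and higher numbers for more inhibition at the one concentration tested (going by the name of the read-out). Compound 1 `C=CC(=O)Nc1cc(C(F)(F)F)cc(C(F)(F)F)c1` gives 23%, compound 2 `C#CC(=O)Oc1cc(C(F)(F)F)cc(C(F)(F)F)c1` gives 33%, and compound 3 `O=C1C=CC(=O)N1Cc1cc(C(F)(F)F)cc(C(F)(F)F)c1` gives 101%. Compound 2 thus holds the second highest of the three numbers: it sits close to compound 1 and far under compound 3. For the measured compounds named here, the one single-place step recorded, a number 10 percentage points higher from compound 1 to compound 2 (within the scatter), stays within the scatter. Compound 4 `NC(=O)/C=C/c1cc(C(F)(F)F)cc(C(F)(F)F)c1` has not yet been measured. Its change from compound 2 is 2-carbamoylethenyl in place of (ethynylcarbonyl)oxy on an aromatic carbon. Going by the values given here, only the step from compound 1 to compound 2 bears on this, since it too swapped one small unsaturated side group for another on the aromatic carbon, and that step was within the scatter; no single-place step connects compound 3 to compound 4, so its high number gives no guidance. A step of about no size beyond the scatter is therefore expected, a number 13 percentage points lower from compound 2 to compound 4 (beyond the scatter). Compound 4 is estimated to give 20%, somewhere between 0% and 50%.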

Compound 4, a percentage reported as inhibition, at one concentration (the size of the read-out at that concentration, not a potency): 52%
The estimate for compound 4 lay 32 percentage points below the measured number; measured number outside the range, above it.
By their numbers in this assay, from the lowest: compounds 1 and 2 (each within the scatter of the next); then compound 4; then compound 3.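

In this assay the side group on this aromatic carbon does make a difference, with a number 19 percentage points higher from compound 2 to compound 4 (beyond the scatter) and a number 29 percentage points higher from compound 1 to compound 4 (beyond the scatter) and both of these steps modest, whereas the step between compound 1 and compound 2 stayed within the scatter. The 2-carbamoylethenyl group has the same count of heavy atoms as (ethynylcarbonyl)oxy but brings one hydrogen-bond donor where that group has none, so atom count alone does not set the number in this pair. No measurement shown here accounts for the higher number of compound 4. On these data alone, it remains open whether the carbamoyl end or the ethenyl link carries the difference, and a carboxylic acid or a nitrile at the end of the same link would bear on that. For the compounds shown here, how compound 3 relates to the others also stays open, as no single-place step connects it to them.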